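A few compounds are considered here, and "the series" means these few. Any claim that something is new, unique, unknown or untested is made for them only; others in the source may bear on it.

Measured so far:
compound 1 `Cc1ccc(-c2c(C(=O)N(C)Cc3cc(Cl)cc(Cl)c3)n(C)c(=O)c3ncccc23)cc1`: 3.4 nM in an assay on IM-9 cells for binding affinity to Substance-P receptor (Homo sapiens); a higher number here means a weaker inhibitor, a lower number a stronger inhibitor
compound 2 `CCN(Cc1ccccc1OC)C(=O)c1c(-c2ccccc2C)c2ccccc2c(=O)n1C`: 34 nM in this assay

Of these two values, compound 2 gives the higher number, and its gap to compound 1 lies beyond the usual scatter of this kind of measurement. Compound 3, `COc1ccccc1CN(C)C(=O)c1c(-c2ccccc2C)c2ccccc2c(=O)n1C`, has not yet been measured in this assay. It differs from compound 2 in one place only: hydrogen in place of methyl on a saturated chain carbon bound to an amide-type nitrogen; seen one bond further out, the same change reads as ethyl becoming methyl. Among the measured compounds shown here, no pair of measured compounds shows this change on its own, so the expectation cannot lean on a measured step. Compound 1 does carry methyl rather than ethyl at the matching place and gives the lower of the two numbers, but it differs from compound 2 elsewhere in its structure as well, so it offers no clean reading of the ethyl-to-methyl change. For compound 3 the step of a 2.3-fold lower number from compound 2 to compound 3 (0.36 log units; beyond the scatter) is expected to be a modest gain, one that may still sit within the scatter. Compound 3 is therefore estimated at 15 nM, with a plausible range from 4 nM to 60 nM.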

Compound 3, half-maximal inhibitory concentration: 16 nM
For compound 3 the middle estimate is 1.1-fold (0.03 log units) below the measured one, and the stated range covers the measured number.
By their numbers in this assay, from the lowest: compound 1; then compound 3; then compound 2.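

Read in this assay, the change from ethyl to methyl, that is, hydrogen in place of methyl on a saturated chain carbon bound to an amide-type nitrogen, gives a 2.1-fold lower number from compound 2 to compound 3 (0.33 log units; beyond the scatter). Among the compounds shown here, this is the first reading of the change on its own, since the two compounds differ in this one place and share the same core: removing a single carbon at this place moves the number by a modest step that lies beyond the usual scatter. It rests on one pair of compounds, so it describes this core and no wider pattern, and nothing measured here accounts for the step.

The compounds shown leave open how the number responds to other groups at this place, such as a longer chain like propyl, a ring like cyclopropyl, or the amide hydrogen in place of the whole chain. They also leave open whether the ethyl-to-methyl change would give a step of similar size on the core of compound 1, which carries methyl at the matching place.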